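Working notes on compound 1 and compound 3

The source may report more compounds than this note shows. Statements on the series, on what has been measured and on what is new or still open speak of the compounds shown alone.

Measured compounds:
- compound 1, `C=C(Br)C(=O)Nc1cccc(/C=C2\SC(=O)N(Cc3ccc(C)cc3)C2=O)c1`: 600 nM
- compound 2, `Nc1ccc(/C=C2\SC(=O)N(Cc3cccc(Cl)c3)C2=O)cc1`: 4700 nM

In a functional assay on L1210 cells (Mus musculus) for cytotoxicity, read by cell counting, with a stated time of 2 days (a lower number here means a stronger inhibitor, a higher number a weaker inhibitor), compound 1 gives 600 nM, the lowest of the two numbers recorded so far. Compound 2 gives 4700 nM, a higher number, and the gap between the two lies beyond the scatter. Within the data shown here, no single-place step is counted between these two compounds, as they differ in more than one place, so only their two values are set side by side here.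

The step followed goes from compound 1 to compound 3, `C=C(Br)C(=O)Nc1cccc(/C=C2\SC(=O)N(Cc3ccccc3)C2=O)c1`, which has not yet been measured. The difference is hydrogen in place of methyl on an aromatic carbon. Cut one bond further out it reads 4-methylbenzyl to benzyl. Among the measured compounds shown here, no measured pair in this set carries this change, so nothing in the numbers fixes its size. A change of this kind is expected to move the number little, most likely within the scatter, with a slight lean toward a higher number. The expected step is a 1.5-fold higher number from compound 1 to compound 3 (0.18 log units; within the scatter). Compound 3 is estimated at 900 nM in this assay, with a range of 300 nM to 2700 nM.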

Compound 3, half-maximal inhibitory concentration: 380 nM
Estimate against measurement, compound 3: 2.4-fold (0.37 log units) above; the range from low to high includes it.
By their numbers in this assay, from the lowest: compounds 3 and 1 (each within the scatter of the next); then compound 2.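

The series now has its first single-place step: in this assay, hydrogen in place of methyl on an aromatic carbon, para to a large group, gives a result that lies within the scatter (a 1.6-fold lower number from compound 1 to compound 3 (0.20 log units; within the scatter)). This read-out therefore does not separate 4-methylbenzyl from benzyl, and the methyl is not needed for compound 3 to stay within the scatter of compound 1, something the earlier pair, with its differences in more than one place, could not show. No accompanying measurement bears on why these two values sit so close.

Going by these compounds, this single step says only that removing the methyl leaves the number within the scatter, and it remains open whether a methoxy group, a carboxylic acid or a longer chain such as butyl at the same place would do the same. Compound 2 still differs from compound 1 and compound 3 in more than one place, so the contribution of each of those differences to its higher number cannot be separated.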